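This account rests on a few compounds, and the source may have more. Where it says the series, first, only, none or still open, it means among the compounds named here.

Measured so far in an ADME assay on HepG2 2.2.15 cells (Homo sapiens) for cytotoxicity, read by MTT assay, with a stated time of 8 days; a lower number here means that less compound is tolerated, a higher number that more compound is tolerated:

- compound 1, `N#Cc1ccc(Cn2nc(-c3cc(Cl)c(NCC(O)CO)nc3F)c3ccccc3c2=O)cc1`: > 100000 nM
- compound 2, `O=C(O)c1cc(-c2ccc(F)nc2F)nn(Cc2ccc(Cl)cc2)c1=O`: > 100000 nM

Both numbers are limits of the assay rather than measured values. For compound 1 the result of > 100000 nM means that no half-maximal cytotoxic concentration was reached within the range tested. The same holds for compound 2, whose > 100000 nM is also a limit. Compound 1 therefore stands at the limit of > 100000 nM in this assay, at which 2 of the 2 values shown sit, and nothing places it higher or lower than compound 2.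

Compound 3, `COC(=O)CCNc1nc(F)c(-c2nn(Cc3ccc(C#N)cc3)c(=O)c3ccccc23)cc1Cl`, is not yet measured. For the measured compounds named here, it differs from compound 1 in one place: (methoxycarbonyl)methyl in place of 1,2-dihydroxyethyl on a saturated chain carbon bound to a nitrogen on an aromatic ring No step between two measured compounds is available that would show how such a change moves this assay. Because compound 1 sits at the limit of > 100000 nM in this assay, at which 2 of the 2 values shown sit, the expected result for compound 3 is no change beyond the scatter, as a step of a number no higher from compound 1 to compound 3 (the limit leaves the size open) in this assay. Compound 3 is therefore estimated at 100000 nM, within a range from 30000 nM to 300000 nM, with a good chance that only a limit is again reported.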

Compound 3, half-maximal cytotoxic concentration: > 100000 nM
Compound 3 gave a limit, no number; the forecaster's own chance of this, stated with the estimate: 80%; the middle value sits exactly at the limit.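

In this assay compound 3 gives > 100000 nM as a limit of the assay. Compound 1 also gives only a limit, and no step can be read between compound 1 and compound 3. Still open are the size of any effect of (methoxycarbonyl)methyl in place of 1,2-dihydroxyethyl and how compound 1, compound 2 and compound 3 would rank, since all stand together: the limit of > 100000 nM in this assay, at which 3 of the 3 values shown sit.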